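A few compounds are considered here, and "the series" means these few. Any claim that something is new, unique, unknown or untested is made for them only; others in the source may bear on it.

Values so far in an ADME assay for permeability, using PAMPA, at pH 5.5 (a higher number here means that the compound crosses the layer faster, a lower number that the compound crosses the layer more slowly), stand as follows.

compound 1 `CC(C)COc1ncc(-c2cn(C)c3cc(C(=O)NS(C)(=O)=O)ccc23)cc1Cl` gives 443 nm/s
compound 2 `CC(C)COc1ncc(-c2cn(C)c3cc(C(=O)NS(=O)(=O)C4CC4)c(F)cc23)cc1Cl` gives 335 nm/s
compound 3 `CC(C)COc1ccc(-c2cn(C)c3cc(C(=O)NS(C)(=O)=O)c(F)cc23)cn1` gives 802 nm/s

Compound 3 holds the top number of the three, but its gap to compound 1 lies within the scatter, so those two cannot be ranked. Only compound 2 sits lower than compound 3 by more than the scatter.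

The next compound to read is compound 4 `CC(C)COc1ncc(-c2cn(C)c3cc(C(=O)NS(C)(=O)=O)c(F)cc23)cc1Cl`, which carries a single change on compound 3: chloro in place of hydrogen on an aromatic carbon.

Within the data shown here, no measured pair shows this change on its own, so any expectation rests on indirect evidence. Among the measured compounds shown here, compound 4 gains the chloro already carried by compound 1 at 443 nm/s and by compound 2 at 335 nm/s, and both of these numbers stand under the one for compound 3. For the measured compounds named here, with only two such compounds, that is a weak guide. In this assay the expected step is downward and modest, an estimated 1.8-fold lower number from compound 3 to compound 4 (0.25 log units; within the scatter) of about the size of the scatter. The estimate for compound 4 is 450 nm/s with an expected range from 220 nm/s to 900 nm/s for the measurement.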

Compound 4, apparent permeability: 495 nm/s
For compound 4 the middle estimate is 1.1-fold (0.04 log units) below the measured one, and the stated range covers the measured number.
By their numbers in this assay, from the lowest: compounds 2, 1, 4 and 3 (each within the scatter of the next, the first and the last beyond it).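

In this assay, the chloro in place of hydrogen on an aromatic carbon, ortho to an isobutoxy group and two atoms from the ring nitrogen, can now be read on its own: a 1.6-fold lower number from compound 3 to compound 4 (0.21 log units; within the scatter) is the step, and this position takes the chloro without a change beyond the scatter. Among these compounds, compound 4 also gives the first single-change readings at two other places, with methyl in place of cyclopropyl on a sulfonyl sulfur as a 1.5-fold higher number from compound 2 to compound 4 (0.17 log units; within the scatter) and the gain of a fluoro as a 1.1-fold higher number from compound 1 to compound 4 (0.05 log units; within the scatter) so that none of the three single changes around compound 4 stands beyond the scatter. Nothing measured here bears on what lies behind these steps.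

Still open, on these data alone, is whether a bromo, a nitrile or an amine on the same aromatic carbon would give a step beyond the scatter in this assay and whether a longer chain in place of the isobutoxy group would alter the step seen for chloro. Also open, as far as these compounds go, is whether the chloro step keeps its size with cyclopropyl on the sulfonyl sulfur or without the fluoro.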